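Compound 3 to compound 4: hydroxy replaced by hydrogen

This account rests on a few compounds, and the source may have more. Where it says the series, first, only, none or still open, it means among the compounds named here.

Measured in a functional assay on A549 cells (Homo sapiens) for antiproliferative activity, read by MTT assay, with a stated time of 48 h; a higher number here means a weaker inhibitor, a lower number a stronger inhibitor:
- compound 1 `C=C(C(=O)O)[C@@H]1CC[C@]2(C)C(=C(C)C(=O)C[C@H]2O)C1`: > 100000 nM (a limit)
- compound 2 `C=C(C(=O)O)[C@@H]1CC[C@@]2(C)C[C@H](O)C(=O)C(C)=C2C1`: > 100000 nM (a limit)
- compound 3 `C=C(C(=O)O)[C@@H]1CC[C@@]2(C)C=C(O)C(=O)C(C)=C2C1`: > 100000 nM (a limit)

Compound 3 stands at > 100000 nM, which is a limit and not a number. Among the compounds with values here, nothing gives it a numerical neighbour, and the only evidence is the limit of > 100000 nM in this assay, at which 3 of the 3 values shown sit.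

Compound 4 `C=C(C(=O)O)[C@@H]1CC[C@@]2(C)C=CC(=O)C(C)=C2C1` carries hydrogen in place of hydroxy on a double-bonded ring carbon. Within the data shown here, no measured pair isolates this change, so no step size can be taken from the data in this assay. The working expectation is no step beyond the scatter, in either direction. That expectation rests on compound 3 at > 100000 nM. The estimated change is a number no higher from compound 3 to compound 4 (the limit leaves the size open). For compound 4 the expected value is 100000 nM, with an estimated range of 40000 nM to 200000 nM. A reading that again gives only a limit is the likeliest outcome.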

Compound 4, half-maximal inhibitory concentration: > 100000 nM
Compound 4: no number, only a limit; the forecaster's own chance of this, stated with the estimate: 75%; the middle value lies on the limit itself.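

No step can be read from compound 3 to compound 4: each gives only a limit in this assay. The compounds shown leave open which change to the shared core, if any, would give a measurable value, as all remain at the limit: the limit of > 100000 nM in this assay, at which 4 of the 4 values shown sit.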